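Swapping a Tetrazole for a Carboxylic Acid

The source may report more compounds than this note shows. Statements on the series, on what has been measured and on what is new or still open speak of the compounds shown alone.

Compound 1 `CCCS(=O)(=O)Nc1ccc(F)c(C(=O)c2n[nH]c3ncc(-c4cccc(Cl)c4)cc23)c1F` gives 40% in an assay for binding affinity to dual specificity mitogen-activated protein kinase kinase 4 (Homo sapiens), read by KINOMEscan, tested at 100 nM; a higher number here means a weaker effect of the compound at the concentration tested, a lower number a stronger effect.
Compound 2 `CCCS(=O)(=O)Nc1ccc(F)c(C(=O)c2n[nH]c3ncc(-c4cccc(O)c4)cc23)c1F` gives 2.2% in this assay.
Compound 3 `CCCS(=O)(=O)Nc1ccc(F)c(C(=O)c2n[nH]c3ncc(-c4ccc(-c5nnn[nH]5)cc4)cc23)c1F` gives 0.15% in this assay.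

Compound 3 has the lowest of the three numbers. Its nearest neighbour is compound 2, the two lying within the scatter of each other: a number 2.1 percentage points lower from compound 2 to compound 3 (within the scatter). Compound 1 lies far away: a number 39.9 percentage points lower from compound 1 to compound 3 (beyond the scatter).

Compound 4 `CCCS(=O)(=O)Nc1ccc(F)c(C(=O)c2n[nH]c3ncc(-c4ccc(C(=O)O)cc4)cc23)c1F` differs from compound 3 by one change: carboxy in place of 1H-tetrazol-5-yl on an aromatic carbon.

Within the data shown here, two measured steps bear on this outer ring. Replacing chloro by hydroxy gave a large drop, a number 37.8 percentage points lower from compound 1 to compound 2 (beyond the scatter), and replacing 3-chlorophenyl by 4-(1H-tetrazol-5-yl)phenyl gave a drop of the same size, a number 39.9 percentage points lower from compound 1 to compound 3 (beyond the scatter). Among the measured compounds shown here, no measured step swaps 1H-tetrazol-5-yl for carboxy, so direct evidence is lacking; the two groups carrying a hydrogen-bond donor on this ring both sit at the low end. Compound 4 is therefore expected to stay near compound 3, with a step of a number 1.4 percentage points higher from compound 3 to compound 4 (within the scatter). The estimate for compound 4 is 1.5%, in a range from 0.1% to 15%.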

Compound 4, a percentage reported as activity, at one concentration (the size of the read-out at that concentration, not a potency): 0.1%
The estimate for compound 4 lay 1.4 percentage points above the measured number; the measured number falls inside the stated range.
By their numbers in this assay, from the lowest: compounds 4, 3 and 2 (each within the scatter of the next); then compound 1.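

On this ring, carboxy, with 3 heavy atoms and no ring of its own, can take the place of the five-membered 1H-tetrazol-5-yl without a change that can be read in this assay: a number 0.1 percentage points lower from compound 3 to compound 4 (within the scatter). The 4-carboxyphenyl group also cannot be told apart from 3-hydroxyphenyl, a number 2.1 percentage points lower from compound 2 to compound 4 (within the scatter), whereas the gap from 3-chlorophenyl is large, a number 39.9 percentage points lower from compound 1 to compound 4 (beyond the scatter), so among these four compounds only compound 1 stands apart. Nothing available here explains why these three groups give such similar results.

The compounds shown leave open whether an amine, a methyl ester or a primary amide in place of carboxy would keep the number this low. They also leave open whether carboxy would do the same at the end of a longer chain.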